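The compounds below may be only part of what the source reports. "The series", "measured", "known", "first", "only" and "open" are said of these compounds alone.

Measured so far in a functional assay on SK-MEL-2 cells (Homo sapiens) for cytotoxicity; a lower number here means that less compound is needed, a higher number that more compound is needed for the effect:
Compound 1 `C=CCCCCCC#CC#C/C(O)=C\C(C)=O` gives 4.21 ug/mL.
Compound 2 `C=CCCCCCCCC#CC#CCOCC(=O)O` gives 4.68 ug/mL.

On these two numbers compound 1 stands within the scatter of compound 2; the pair shows no separation beyond the scatter. Compound 3 `C=CCCCCCC#CC#C/C(O)=C/C(C)=O` has not yet been measured in this assay. Relative to compound 1 it differs as follows: the two compounds have the same atoms and bonds and differ only in configuration as drawn: 1 of 1 stereo elements differ; a double bond is drawn E in compound 1 and Z in compound 3. Within the data shown here, no step between measured compounds is available to gauge what such a change does, so the expectation is a step of a 1.1-fold higher number from compound 1 to compound 3 (0.03 log units; within the scatter) that stays within the scatter, with no direction favored. Compound 3 is therefore expected to give 4.5 ug/mL in this assay, with a range from 2.3 ug/mL to 9 ug/mL.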

Compound 3, concentration for half-maximal effect: 4.61 ug/mL
Beside the measured number, compound 3's estimate is 1.0-fold (0.01 log units) below it; the measured number falls inside the stated range.
By their numbers in this assay, from the lowest: compounds 1, 3 and 2 (each within the scatter of the next).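

In this assay the series now has its first readable step, a 1.1-fold higher number from compound 1 to compound 3 (0.04 log units; within the scatter). At this position, redrawing the double bond from E to Z therefore leaves the two numbers indistinguishable, which the earlier pair, differing in more than one place, could not show. This step isolates configuration alone: the fact that compounds 1 and 3 differ only in the configuration as drawn

Still open, going by these compounds, is whether an amine or an amide in place of the hydroxyl on this double bond, on the core of compound 1, would give a step beyond the scatter. The same question holds for a methyl ether at that hydroxyl.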